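Moving the chlorine on the triazole aryl group

The source may hold more compounds than are shown below. What is called first, only, known or untested is meant among the compounds shown, and "the series" means these compounds.

Compound 1, `O=c1[nH]cc(S(=O)(=O)Nc2cccc(-c3cn(-c4ccc(F)cc4)nn3)c2)c(=O)[nH]1`: > 20000 nM
Compound 2, `O=c1[nH]cc(S(=O)(=O)Nc2cccc(-c3cn(-c4ccccc4Cl)nn3)c2)c(=O)[nH]1`: 3010 nM

In a functional assay on SGC-7901 cells (Homo sapiens) for antiproliferative activity, read by MTT assay, with a stated time of 24 h (on this read-out lower numbers stand for stronger inhibition and higher numbers for weaker inhibition), compound 1 shows > 20000 nM, which is the limit of > 20000 nM in this assay, at which 1 of the 2 values shown sits, and so a limit of the assay rather than a number. Compound 2 gives 3010 nM, the only true number shown, and the step of an at least 6.6-fold lower number from compound 1 to compound 2 (0.82 log units; beyond the scatter) changes both the halogen and its position at once. Compound 3 `O=c1[nH]cc(S(=O)(=O)Nc2cccc(-c3cn(-c4cccc(Cl)c4)nn3)c2)c(=O)[nH]1` differs from compound 2 by 3-chlorophenyl in place of 2-chlorophenyl on an aromatic nitrogen. For the measured compounds named here, no measured step moves chlorine alone, so the direction is uncertain. The expected step is a 1.7-fold higher number from compound 2 to compound 3 (0.22 log units; within the scatter). Compound 3 is estimated at 5000 nM, within 1500 nM to 20000 nM.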

Compound 3, half-maximal inhibitory concentration: 3950 nM
Beside the measured number, compound 3's estimate is 1.3-fold (0.10 log units) above it, and the stated range covers the measured number.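

With the halogen held fixed, moving the chlorine in this assay gives a 1.3-fold higher number from compound 2 to compound 3 (0.12 log units; within the scatter) and so shows no readable effect of this shift. Replacing 4-fluorophenyl with 3-chlorophenyl gives an at least 5.0-fold lower number from compound 1 to compound 3 (0.70 log units; beyond the scatter) and so repeats the gain seen with 2-chlorophenyl. Compound 1 holds a limit of the assay, not a number: the limit of > 20000 nM in this assay, at which 1 of the 3 values shown sits.

On these data alone, whether the halogen itself or its place separates compound 1 from compound 2 and compound 3 stays open. So does how a methoxy group or an amine would compare with chlorine on this ring.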